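The compounds below may be only part of what the source reports. "The series", "measured", "known", "first", "only" and "open" are said of these compounds alone.

Measured so far in a functional assay on HEK293 cells for agonist activity at D(4) dopamine receptor (Homo sapiens), read by FLIPR; on this read-out higher numbers stand for an effect only at larger amounts of compound and lower numbers for an effect already at smaller amounts:

compound 1 `Cc1cccc(NC(=O)CN2CCC(c3ccccc3C#N)CC2)c1` — 8 nM
compound 2 `Cc1ccc(C(=O)NCN2CCC(c3cccc[n+]3[O-])CC2)cc1C` — 38 nM
compound 3 `Oc1ccc(N2CCN(Cc3nc4ccccc4[nH]3)CC2)nc1` — 2.4 nM

Among these three, compound 2 stands at the highest number in this assay. Compound 1 gives a lower number, and the gap lies beyond the scatter; compound 3 gives a lower number still, and that gap too lies beyond the scatter. No two of the measured compounds differ in only one place, so none of them offers a single step that could serve as a guide.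

Compound 4 `O=C(NCN1CCC(c2cccc[n+]2[O-])CC1)c1ccccn1` has not yet been measured in this assay. It is built from compound 2 by one change: pyridin-2-yl in place of 3,4-dimethylphenyl on a carbonyl carbon. The change sits on a carbonyl carbon whose other neighbour is an amide-type nitrogen; the rest of the molecule is kept. Within the data shown here, nothing among the measured compounds shows what this exchange does in this assay, as they differ from one another in several places at once. On that footing one expects the step of a 1.6-fold higher number from compound 2 to compound 4 (0.20 log units; within the scatter) to stay within the usual scatter, leaning if anything toward a somewhat higher number. Compound 4 is accordingly estimated at about 60 nM in this assay, with a likely range from 15 nM to 250 nM.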

Compound 4, half-maximal effective concentration: 3150 nM
Compound 4: the middle estimate sits 53-fold (1.72 log units) below what was measured; the measured number lies above the stated range.
By their numbers in this assay, from the lowest: compound 3; then compound 1; then compound 2; then compound 4.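

In this assay, the group on a carbonyl carbon whose other neighbour is an amide-type nitrogen proves to matter a great deal: pyridin-2-yl in place of 3,4-dimethylphenyl gives an 83-fold higher number from compound 2 to compound 4 (1.92 log units; beyond the scatter) and this is a large step. Among these compounds, it is the first single change that can be read in this set, and it shows that this place is far from indifferent to the group it carries, even though one six-membered aromatic ring simply replaces another. The entering group has fewer heavy atoms, a ring nitrogen and a hydrogen-bond acceptor, but nothing available separates these differences or gives a reason for the step.

What the compounds shown leave open is whether the step follows from the ring nitrogen or from the absence of the two methyl groups, a question that a plain phenyl group or a 3-methylphenyl group at this place would help to settle. From the compounds shown here alone, it also remains open whether a pyridin-3-yl group would behave like pyridin-2-yl, and whether the exchange would have a similar effect with a different core.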